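Shortening a carbamate chain in an antiproliferative series

The source may report more compounds than this note shows. Statements on the series, on what has been measured and on what is new or still open speak of the compounds shown alone.

Compound 1 `CC(C)(C)OC(=O)NCCC[C@@H]1N=C2C[C@@H]3C[C@@H](C3(C)C)[C@]2(C)OC1=O`: 4100 nM
Compound 2 `CC(C)(C)OC(=O)NCCCC[C@H]1N=C2C[C@H]3C[C@H](C3(C)C)[C@@]2(C)OC1=O`: 14500 nM

In a functional assay on EL4 cells (Mus musculus) for antiproliferative activity, read by sulforhodamine B assay, with a stated time of 48 h (on this read-out lower numbers stand for stronger inhibition and higher numbers for weaker inhibition), compound 2 stands at the higher of the two numbers, and its gap to compound 1 lies beyond the usual scatter. Compound 3 `CC(C)(C)OC(=O)NCCC[C@H]1N=C2C[C@H]3C[C@H](C3(C)C)[C@@]2(C)OC1=O` differs from compound 2 by (tert-butoxycarbonyl)amino in place of ((tert-butoxycarbonyl)amino)methyl on a saturated chain carbon, three bonds along the chain from a saturated ring carbon. Going by the values given here, no measured pair isolates this change, so its effect is open; compound 1, which also carries the shorter chain, gives 4100 nM. Compound 3 is therefore expected near 7000 nM, within 2000 nM to 25000 nM. The expected step is a 2.1-fold lower number from compound 2 to compound 3 (0.32 log units; beyond the scatter), a modest move toward stronger inhibition, possibly none beyond the scatter.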

Compound 3, half-maximal inhibitory concentration: 48000 nM
Estimate against measurement, compound 3: 6.9-fold (0.84 log units) below, outside the stated range (above it).
By their numbers in this assay, from the lowest: compound 1; then compound 2; then compound 3.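

With the configuration held, the shorter chain gives a 3.3-fold higher number from compound 2 to compound 3 (0.52 log units; beyond the scatter) in this assay, so in this pair shortening the chain weakens inhibition. At the shorter chain length, the mirror-image pair gives a 12-fold higher number from compound 1 to compound 3 (1.07 log units; beyond the scatter), which makes the drawn configuration matter in this assay. That larger step can be read as an effect of configuration alone: the fact that compounds 1 and 3 differ only in the configuration as drawn. Still open, on these data alone, is whether the chain length has the same effect in the configuration of compound 1, and whether a free amine in place of the carbamate would retain activity.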